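From 4-methylphenyl to pyridin-2-yl on the shared core

This account rests on a few compounds, and the source may have more. Where it says the series, first, only, none or still open, it means among the compounds named here.

These notes cover compound 1 (`Cc1ccccc1Nc1nc(NC2CC2)ncc1Cl`), compound 2 (`Cc1ccc(Nc2ncc(Cl)c(Nc3ccccc3C)n2)cc1`) and the unmeasured compound 3 (`Cc1ccccc1Nc1nc(Nc2ccccn2)ncc1Cl`). In a functional assay on MCF7 cells (Homo sapiens) for inhibition, read by CCK-8 assay, with a stated time of 48 h (a lower number here means a stronger inhibitor of growth, a higher number a weaker inhibitor of growth), compound 1 gives > 100000 nM as a limit of the assay and not a number. In this assay compound 2 gives > 100000 nM as a limit as well, so compound 2 stands without a number. The further value shown is also a limit.

Compound 3 carries pyridin-2-yl in place of 4-methylphenyl on a nitrogen on an aromatic ring. For the measured compounds named here, the one measured step at this place is a step that the two limits leave unreadable from compound 1 to compound 2 and it offers no size to carry over. The whole of the evidence so far is the limit of > 100000 nM in this assay, at which 2 of the 2 values shown sit, and it gives no direction.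

Taking compound 2 with its limit of > 100000 nM as the starting point, no step beyond the scatter is expected, and a further limit is the likeliest report. The estimated step is a number no higher from compound 2 to compound 3 (the limit leaves the size open) in this assay with no direction expected. For compound 3 the expected value is 100000 nM with an estimated range from 30000 nM to 200000 nM in this assay as the working figure.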

Compound 3, concentration for 50% growth inhibition: 31400 nM
Compound 3: middle estimate off by 3.2-fold (0.50 log units), on the high side, within the range that was stated.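

For the compounds shown here, at this place, on a nitrogen on an aromatic ring, the earlier compounds gave no readable change in this assay, whereas pyridin-2-yl in place of 4-methylphenyl gives an at least 3.1-fold lower number from compound 2 to compound 3 (0.50 log units; beyond the scatter). Pyridin-2-yl in place of cyclopropyl gives an at least 3.1-fold lower number from compound 1 to compound 3 (0.50 log units; beyond the scatter), so the entering group shows the same direction against both groups it replaces, and the step between compound 1 and compound 2 remains unreadable. The change to pyridin-2-yl shows that a number can be reached at this place on the shared core, yet it brings a ring nitrogen and a hydrogen-bond acceptor together, and no cause can be assigned to either, while the series still sits largely at the limit: the limit of > 100000 nM in this assay, at which 2 of the 3 values shown sit.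

From the compounds shown here alone, whether the ring nitrogen itself carries the step stays open, and pyridin-3-yl or pyridin-4-yl at this place, or a phenyl ring bearing an amine or a carboxylic acid, would be needed to separate its contribution from that of the ring as a whole. Going by these compounds, the full size of both steps also stays open, with compound 1 and compound 2 standing only at limits of the assay.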